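The source may report more compounds than this note shows. Statements on the series, on what has been measured and on what is new or still open speak of the compounds shown alone.

Measured in a physicochemical assay on A549 cells for solubility, read by microscopy, with a stated time of 24 h; a higher number here means a weaker inhibitor, a lower number a stronger inhibitor:
compound 1 `O=C(N/N=C/c1ccco1)c1cc(-c2ccccc2)nn1Cc1ccccc1`, 8780 nM
compound 3 `O=C(N/N=C/c1ccco1)c1cc(-c2ccccc2)nn1Cc1ccc(Cl)nc1`, 19400 nM
compound 2 `COc1ccc(/C=N/NC(=O)c2cc(-c3ccccc3)nn2Cc2ccc(Cl)nc2)cc1`, "not determined" (no result reported)

Compound 3 stands at the higher of the two numbers available; compound 1 is its nearest neighbour, and the change between them, a 2.2-fold higher number from compound 1 to compound 3 (0.34 log units; beyond the scatter), is modest but beyond the scatter. Compound 4 `COc1ccc(-c2cc(C(=O)N/N=C/c3ccco3)n(Cc3ccc(Cl)nc3)n2)cc1` differs from compound 3 only by methoxy in place of hydrogen on an aromatic carbon. Among the compounds with values here, no measured step bears on this part of the structure: the one measured step concerns the group on the saturated chain carbon bound to an aromatic nitrogen, and compound 2, which also carries a methoxy, gave no result in this assay. Within the data shown here, with no comparable step to draw on, the change from compound 3 to compound 4 is expected to stay within the scatter, a 1.0-fold lower number from compound 3 to compound 4 (0.01 log units; within the scatter). Compound 4 is therefore estimated at 19000 nM, with a range from 8000 nM to 45000 nM.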

Compound 4, half-maximal inhibitory concentration: 15800 nM
The estimate for compound 4 lay 1.2-fold (0.08 log units) above the measured number, within the range that was stated.
By their numbers in this assay, from the lowest: compounds 1, 4 and 3 (each within the scatter of the next, the first and the last beyond it).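

Placing methoxy on the aromatic carbon para to a large group, turning phenyl into 4-methoxyphenyl, gives a 1.2-fold lower number from compound 3 to compound 4 (0.09 log units; within the scatter) in this assay. Within the data shown here, this is the first measured step at this position, and it shows that the methoxy group can be carried there without leaving the scatter, whereas the earlier step concerned the group on the saturated chain carbon. No evidence accompanies this result to account for it.

Going by these compounds, whether an amine or a carboxylic acid at the same place would shift the number remains open. So does whether methoxy would behave alike on compound 1 .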